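The source may hold more compounds than are shown below. What is called first, only, known or untested is meant among the compounds shown, and "the series" means these compounds.

Of the compounds shown here, three on a shared core have been measured in an ADME assay on LLC-MK2 cells (Macaca mulatta) for cytotoxicity, read by spectrophotometry and crystal violet staining, with a stated time of 4 days; a lower number here means that less compound is tolerated, a higher number that more compound is tolerated. Compound 3 (`CC(C)n1ncc2c(C(=O)Nc3ccncc3)cc(-c3cccs3)nc21`) gives 6300 nM. Compound 1 (`CC(C)n1ncc2c(C(=O)Nc3ccccn3)cc(-c3ccccc3)nc21`) gives 12500 nM, within the usual scatter of compound 3. Compound 2 (`CC(C)n1ncc2c(NC(=O)c3ccc(F)cc3)cc(-c3cccs3)nc21`) gives 50000 nM, a higher number than that of compound 3 and beyond the scatter.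

Compound 4 (`CC(C)n1ncc2c(C(=O)Nc3ccccc3F)cc(-c3cccs3)nc21`) differs from compound 3 in one place: 2-fluorophenyl in place of pyridin-4-yl on an amide-type nitrogen. In words, 2-fluorophenyl stands in place of pyridin-4-yl on an amide-type nitrogen. Going by the values given here, no measured pair differs in one place only, so the size of this change has no direct precedent. The loose guide is compound 2, at 50000 nM, whose amide carries an aromatic ring of carbon only, although its amide is turned round. A modest rise in this assay is therefore expected, of about the size of the scatter. The estimate is a 1.9-fold higher number from compound 3 to compound 4 (0.28 log units; within the scatter), an expected step that remains uncertain. The expected value for compound 4 is 12000 nM, with an estimated range of 4000 nM to 40000 nM.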

Compound 4, half-maximal cytotoxic concentration: 50000 nM
Compound 4: middle estimate off by 4.2-fold (0.62 log units), on the low side; the measured number lies above the stated range.
By their numbers in this assay, from the lowest: compounds 3 and 1 (each within the scatter of the next); then compounds 2 and 4 (each within the scatter of the next).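

In this assay, the group on the amide-type nitrogen proves able to shift the number on its own: a 7.9-fold higher number from compound 3 to compound 4 (0.90 log units; beyond the scatter), with 2-fluorophenyl in place of pyridin-4-yl. Going by these compounds alone, this is the first step in the set that changes one place only, and it shows that this swap, with everything else on the shared core held fixed, leads to more compound being tolerated. Nothing available explains why the number rises at this position.

The swap removes the ring nitrogen and brings in fluorine together, so the compounds shown do not separate the two parts of the change. Also open, as far as these compounds go, is how a cyclohexyl or benzyl group on the same amide-type nitrogen would fare, and whether the step would keep its size with a different group elsewhere on the core.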